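From azetidin-1-yl to (3-fluorophenyl)amino on a shared core

The compounds below may be only part of what the source reports. "The series", "measured", "known", "first", "only" and "open" are said of these compounds alone.

In a functional assay on MCF7 cells (Homo sapiens) for inhibition, read by sulforhodamine B assay (on this read-out higher numbers stand for weaker inhibition and lower numbers for stronger inhibition), compound 3 `O=C1C=C(N2CCC2)C(=O)c2c1nc1n2[C@H]2OC[C@@H](O)[C@H]2OC1` gives > 16000 nM, which is a limit and not a number. Compound 4 `O=C1C=C(Nc2cccc(F)c2)C(=O)c2c1nc1n2[C@H]2OC[C@@H](O)[C@H]2OC1` carries (3-fluorophenyl)amino in place of azetidin-1-yl on a double-bonded ring carbon. The nearest comparisons are not one change away from compound 4, though both bear an aromatic ring on an amino group. Compound 1 `O=C1C(Nc2ccccc2F)=CC(=O)c2c1nc1n2[C@H]2OC[C@@H](O)[C@H]2OC1` gives > 4000 nM, also a limit. Compound 2 `O=C1C(Nc2ccccc2)=CC(=O)c2c1nc1n2[C@H]2OC[C@@H](O)[C@H]2OC1` gives > 4000 nM, again a limit, so this kind of group has shown no measurable strength. Within the data shown here, the only measured step, a step that the two limits leave unreadable from compound 1 to compound 2, offers no usable size. Weak inhibition is therefore expected, possibly reported only as another limit. The estimated step, uncertain in size, is an at least 2.0-fold lower number from compound 3 to compound 4 (0.30 log units; that floor lies within the scatter). The expected value for compound 4 is 8000 nM, with an estimated range from 2000 nM to 30000 nM.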

Compound 4, half-maximal inhibitory concentration: 5500 nM
Beside the measured number, compound 4's estimate is 1.5-fold (0.16 log units) above it; the measured number falls inside the stated range.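

In this assay, (3-fluorophenyl)amino in place of azetidin-1-yl gives an at least 2.9-fold lower number from compound 3 to compound 4 (0.46 log units; beyond the scatter), so the group on this double-bonded ring carbon can move the read-out beyond the scatter. Compound 4 is also the first compound shown with a number and not a limit. The full size of the step stays unknown because compound 3 has only a limit: the limit of > 16000 nM in this assay, at which 1 of the 4 values shown sits.

From the compounds shown here alone, whether the change depends on the aromatic ring, its fluoro group or the amino hydrogen remains open. So does the effect of a morpholin-4-yl or dimethylamino group here.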